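A few compounds are considered here, and "the series" means these few. Any claim that something is new, unique, unknown or untested is made for them only; others in the source may bear on it.

Compound 3 `CC/C=C/C(=O)Nc1cccc(Oc2nc(Nc3cccc(OC)c3)nc3ccsc23)c1` is one of three members of this series with a number in a functional assay on MCF7 cells (Homo sapiens) for inhibition, read by MTT assay, with a stated time of 72 h; a higher number here means a weaker inhibitor, a lower number a stronger inhibitor. In this assay compound 3 gives 43400 nM, the higher of the two numbers recorded. For the measured compounds named here, compound 2 `C=CC(=O)Nc1cccc(Oc2nc(Nc3cccc(OC)c3)nc3ccsc23)c1` gives 19000 nM in this assay, and the only measured step, a 2.3-fold higher number from compound 2 to compound 3 (0.36 log units; beyond the scatter), leads from it to compound 3. Compound 1 `COc1ccc(Nc2nc(Oc3cccc(NC(=O)/C=C/C(C)C)c3)c3sccc3n2)cc1` in this assay gives > 50000 nM, which is a limit of the assay rather than a number; the relevant line is the limit of > 50000 nM in this assay, at which 1 of the 3 values shown sits. Compound 1 carries the same (3-methylbut-1-en-1-yl)carbonyl group that compound 4 will carry, though the methoxy is placed differently.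

Compound 4 `COc1cccc(Nc2nc(Oc3cccc(NC(=O)/C=C/C(C)C)c3)c3sccc3n2)c1` is the compound still to be measured. It differs from compound 3 by methyl in place of hydrogen on a saturated chain carbon bound to a double-bonded chain carbon and a saturated chain carbon. Going by the values given here, the one measured step, a 2.3-fold higher number from compound 2 to compound 3 (0.36 log units; beyond the scatter), shows that lengthening the chain on the carbonyl carbon raised the number by a modest amount. A further methyl on the chain is therefore expected to move the number in the same direction, by a step of about a 1.5-fold higher number from compound 3 to compound 4 (0.18 log units; within the scatter), and the outcome for compound 1 suggests the result may itself sit at the limit. Compound 4 is thus estimated to give 65000 nM in this assay, within a range of 30000 nM to 150000 nM.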

Compound 4, half-maximal inhibitory concentration: 43900 nM
Beside the measured number, compound 4's estimate is 1.5-fold (0.17 log units) above it; low and high end bracket the measured number.
By their numbers in this assay, from the lowest: compound 2; then compounds 3 and 4 (each within the scatter of the next). At a limit, above all of these: compound 1.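

In this assay, methyl in place of hydrogen on a saturated chain carbon bound to a double-bonded chain carbon and a saturated chain carbon gives a 1.0-fold higher number from compound 3 to compound 4 (0.00 log units; within the scatter), so this added methyl does not separate the two compounds, whereas the earlier step away from vinyl on the carbonyl carbon was beyond the scatter. The larger replacement, 3-methylbut-1-en-1-yl in place of vinyl on a carbonyl carbon, gives a 2.3-fold higher number from compound 2 to compound 4 (0.36 log units; beyond the scatter), which matches the size of the step to but-1-en-1-yl, so among these compounds it is the vinyl compound that stands apart. With 3-methoxyphenyl in place of 4-methoxyphenyl on a nitrogen on an aromatic ring, the step is an at least 1.1-fold lower number from compound 1 to compound 4 (0.05 log units; that floor lies within the scatter), and it rests on a limit of the assay: the limit of > 50000 nM in this assay, at which 1 of the 4 values shown sits.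

The compounds shown leave open whether a still longer chain on the carbonyl carbon would read like these two substituted chains in this assay. They also leave open how a dimethylamino group at the end of the chain would read there, or a saturated propyl chain in place of the but-1-en-1-yl group.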